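A few compounds are considered here, and "the series" means these few. Any claim that something is new, unique, unknown or untested is made for them only; others in the source may bear on it.

Values so far in a functional assay, read by spectrophotometry, with a stated time of 30 min; on this read-out lower numbers stand for an effect already at smaller amounts and higher numbers for an effect only at larger amounts of compound
- compound 1 `COc1cc(/C=C/C(=O)/C=C(/C=C/c2ccc(O)c(OC)c2)NCCO)ccc1O` gives 28300 nM
- compound 2 `COc1cc(/C=C/C2=CC(=O)CC(c3ccc(O)c(OC)c3)N2CCCO)ccc1O` gives 33900 nM
- compound 3 `O=C(/C=C(/C=C/c1ccc(O)cc1)NCCCO)/C=C/c1ccc(O)cc1` gives 154000 nM

Compound 1 and compound 2 share the low end of these three numbers and lie within the scatter of each other. Compound 3 carries a number beyond the scatter above that of compound 1. For the measured compounds named here, no measured pair differs in one place only, so the series offers no direct precedent for a single change.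

The next compound to be read is compound 4 `COCCNC(=C\C(=O)/C=C/c1ccc(O)c(OC)c1)/C=C/c1ccc(O)c(OC)c1`, which departs from compound 1 at one place: 2-hydroxyethyl becomes 2-methoxyethyl, with methyl in place of hydrogen on an oxygen on a saturated carbon. In this assay no step beyond the scatter is expected from this change, and no direction is favoured. The estimated step of a 1.1-fold higher number from compound 1 to compound 4 (0.03 log units; within the scatter) is therefore expected to be small. For compound 4 the estimated value is 30000 nM with an expected range from 13000 nM to 70000 nM in repeated measurements.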

Compound 4, half-maximal effective concentration: 27300 nM
Compound 4: middle estimate off by 1.1-fold (0.04 log units), on the high side, within the range that was stated.
By their numbers in this assay, from the lowest: compounds 4, 1 and 2 (each within the scatter of the next); then compound 3.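

Going from 2-hydroxyethyl to 2-methoxyethyl in this assay gives a 1.0-fold lower number from compound 1 to compound 4 (0.02 log units; within the scatter) and is the first step in the series that differs in one place only. At this position, the hydrogen on the oxygen can therefore be replaced by methyl without a step beyond the scatter, so a free hydroxy is not required to keep the number at the level of compound 1. No available measurement bears on why the two compounds read alike.

On these data alone, it remains open whether the same holds for a longer chain, such as 2-ethoxyethyl, or for a different end group, such as an amine or a carboxylic acid, at this place. As far as these compounds go, it is also open whether hydroxy to methoxy reads the same when made on compound 2 or compound 3.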